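This account rests on a few compounds, and the source may have more. Where it says the series, first, only, none or still open, it means among the compounds named here.

Compound 1 `O=C(NCN1CCC(c2cccc[n+]2[O-])CC1)c1cnccc1Cl` gives 1290 nM in a functional assay on HEK293 cells for agonist activity at D(4) dopamine receptor (Homo sapiens), read by FLIPR; a lower number here means that less compound is needed, a higher number that more compound is needed for the effect.
Compound 2 `C=Cc1cccc(C(=O)NCN2CCC(c3cccc[n+]3[O-])CC2)c1` gives 68 nM in this assay.

Within the data shown here, of these two numbers compound 2 has the lower one, and the only measured step, a 19-fold lower number from compound 1 to compound 2 (1.28 log units; beyond the scatter), came with 3-vinylphenyl in place of 4-chloropyridin-3-yl on the carbonyl carbon. Compound 3 `Cc1cccc(C(=O)NCN2CCC(c3cccc[n+]3[O-])CC2)c1` differs from compound 2 by methyl in place of vinyl on an aromatic carbon. That measured step swapped a whole aromatic group and so bears only loosely on this smaller change. A step of about a 1.8-fold higher number from compound 2 to compound 3 (0.25 log units; within the scatter) is therefore expected, likely within or just beyond the scatter, if anything toward a higher number. Compound 3 is estimated at 120 nM, between 40 nM and 400 nM.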

Compound 3, half-maximal effective concentration: 89 nM
Compound 3: middle estimate off by 1.3-fold (0.13 log units), on the high side; the measured number falls inside the stated range.
By their numbers in this assay, from the lowest: compounds 2 and 3 (each within the scatter of the next); then compound 1.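

In this assay, the vinyl double bond turns out not to be needed at this position: methyl serves as well, with a step (a 1.3-fold higher number from compound 2 to compound 3 (0.12 log units; within the scatter)) that stays within the scatter. The gain over the 4-chloropyridin-3-yl group therefore does not depend on vinyl, since 3-methylphenyl also gives a large step (a 14-fold lower number from compound 1 to compound 3 (1.16 log units; beyond the scatter)). Nothing available here explains either step. Going by these compounds, whether an unsubstituted phenyl would keep this low number remains open. So does the outcome with a longer chain such as propyl, or with an amine, at this position.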